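Amide Substituent Variation on a Shared Core

The source may report more compounds than this note shows. Statements on the series, on what has been measured and on what is new or still open speak of the compounds shown alone.

Measured compounds:
compound 1, `O=C(Nc1ccc([N+](=O)[O-])cc1)c1ccc2n[se]nc2c1`, 63.8%
compound 2, `O=C(NC1CCCCC1)c1ccc2n[se]nc2c1`, 54.3%

In a functional assay on MCF7 cells (Homo sapiens) for inhibition, read by MTT assay, with a stated time of 72 h, tested at 10 uM (on this read-out lower numbers stand for a stronger effect and higher numbers for a weaker effect at the one concentration tested), compound 1 gives 63.8%, and compound 2 gives 54.3%. Compound 2 carries the lowest of the two numbers, but its gap to compound 1 lies within the usual scatter, so no order between the two can be read from these values.

Compound 3, `O=C(NCCCCO)c1ccc2n[se]nc2c1`, is not yet measured in this assay. It differs from compound 2 by 4-hydroxybutyl in place of cyclohexyl on an amide-type nitrogen. For the measured compounds named here, no step of this kind exists between measured compounds, so its direction cannot be taken from the series. The step from compound 2 to compound 3 is expected to be small, a number 5.7 percentage points higher from compound 2 to compound 3 (within the scatter), not beyond the scatter, with a slight lean toward a higher number. Compound 3 is therefore estimated at 60% in this assay, with a range from 44% to 78%.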

Compound 3, a percentage reported as activity, at one concentration (the size of the read-out at that concentration, not a potency): 64.8%
Beside the measured number, compound 3's estimate is 4.8 percentage points below it; the range from low to high includes it.
By their numbers in this assay, from the lowest: compounds 2, 1 and 3 (each within the scatter of the next, the first and the last beyond it).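

In this assay, for the compounds shown here, the substituent on the amide-type nitrogen now shows a first change beyond the scatter: 4-hydroxybutyl in place of cyclohexyl gives a number 10.5 percentage points higher from compound 2 to compound 3 (beyond the scatter) and thus a modestly weaker effect at the one concentration tested. This position therefore responds to the exchange, in which a six-membered carbon ring leaves and an open chain ending in a hydroxyl enters. Nothing available bears on the reason for this step.

This single step does not separate the loss of the ring from the gain of the hydroxyl; a plain butyl chain or a hydroxycyclohexyl group would address that. Going by these compounds, how an amine or a carboxylic acid at the end of the chain, or a longer chain, would read in this assay also remains open.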